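Swapping the aryl group at the triazole carbon: what to expect

The source may hold more compounds than are shown below. What is called first, only, known or untested is meant among the compounds shown, and "the series" means these compounds.

Compound 2 `O=C(NO)c1ccc(NCc2nc(-c3cc4ccccc4s3)nn2-c2ccccc2)cc1` gives 6110 nM in a functional assay on MGC-803 cells (Homo sapiens) for antiproliferative activity, read by MTT assay, with a stated time of 72 h; a lower number here means a stronger inhibitor, a higher number a weaker inhibitor. Compound 1 `O=C(NO)c1ccc(NCc2nc(-c3ccc(F)cc3)nn2-c2ccccc2)cc1` gives 8960 nM, and the step of a 1.5-fold lower number from compound 1 to compound 2 (0.17 log units; within the scatter) lies within the scatter, so the two numbers cannot be ranked against each other; compound 2 merely has the lower of the two. Compound 3 `O=C(NO)c1ccc(NCc2nc(-c3ccccc3Cl)nn2-c2ccccc2)cc1` differs from compound 2 by the change (2-chlorophenyl in place of 1-benzothiophen-2-yl on an aromatic carbon). Going by the values given here, the one measured step, a 1.5-fold lower number from compound 1 to compound 2 (0.17 log units; within the scatter), also exchanges the aryl group on this aromatic carbon and produced no change beyond the scatter, so for compound 3 a similarly small step is expected, probably drifting slightly back toward the number of compound 1 but staying inside the scatter. The expected step is a 1.3-fold higher number from compound 2 to compound 3 (0.12 log units; within the scatter). Compound 3 is therefore estimated at 8000 nM, with a range from 4000 nM to 16000 nM.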

Compound 3, half-maximal inhibitory concentration: > 20000 nM
Compound 3: only a limit was reported; the forecaster's own chance of this, stated with the estimate: 5%; middle value at least 2.5-fold (0.39 log units) away from the limit.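

The earlier exchange at this aromatic carbon stayed within the scatter, which could have suggested that the aryl group here matters little. In this assay, the change to 2-chlorophenyl shows otherwise, with an at least 3.2-fold higher number from compound 2 to compound 3 (0.51 log units; beyond the scatter) and an at least 2.2-fold higher number from compound 1 to compound 3 (0.34 log units; beyond the scatter), so the number can respond to which aryl group sits on this carbon. Compound 3 has only a limit, > 20000 nM, and the full size of both steps stays unknown because of it: the limit of > 20000 nM in this assay, at which 1 of the 3 values shown sits.

The 2-chlorophenyl and 4-fluorophenyl groups differ both in their halogen and in where it sits, so the compounds shown cannot separate these two changes. As far as these compounds go, it also remains open whether a plain phenyl group or an aminophenyl group on this carbon would behave like compound 3 or like compound 1 and compound 2.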